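A few compounds are considered here, and "the series" means these few. Any claim that something is new, unique, unknown or untested is made for them only; others in the source may bear on it.

Measured so far, each entry a limit and not a number:
- compound 1 `Cc1ccc(CNc2nc(N)nc3ccn(Cc4ccccn4)c23)nc1`: > 24000 nM
- compound 2 `Nc1nc(NCc2nccs2)c2c(ccn2Cc2ccccn2)n1`: > 24000 nM
- compound 3 `Nc1nc(NCc2ccon2)c2c(ccn2Cc2ccccn2)n1`: > 24000 nM

The read-out here is an ADME assay on HEK293 cells (Homo sapiens) for cytotoxicity, read by ATP content, with a stated time of 6 h; a lower number here means that less compound is tolerated, a higher number that more compound is tolerated. Compound 3 holds only a limit, > 24000 nM, so it offers no number to step from. Going by the values given here, the series so far stands at one place: the limit of > 24000 nM in this assay, at which 3 of the 3 values shown sit.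

Next is compound 4 `Cc1cc(CNc2nc(N)nc3ccn(Cc4ccccn4)c23)no1`: methyl in place of hydrogen on an aromatic carbon. The change is methyl in place of hydrogen on an aromatic carbon.

The measured steps that bear on it exchange the whole ring on the saturated chain carbon: a step that the two limits leave unreadable from compound 1 to compound 2, a step that the two limits leave unreadable from compound 1 to compound 3 and a step that the two limits leave unreadable from compound 2 to compound 3. Among the compounds with values here, none of them has a readable size, and no step that only adds a methyl has been measured. Compound 1 already carries a 5-methylpyridin-2-yl group, and its > 24000 nM is again a limit.

The estimated step is a step that the limit leaves unreadable from compound 3 to compound 4, so no change beyond the scatter and no direction is expected in this assay. For compound 4 the estimated value is 30000 nM, with an expected range from 15000 nM to 60000 nM, and a further limit is the likeliest report.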

Compound 4, half-maximal cytotoxic concentration: > 24000 nM
Compound 4: only a limit was reported (the forecaster's own chance of this, stated with the estimate: 85%); the middle value does not contradict the limit.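

Going by these compounds alone, compound 4 gives > 24000 nM in this assay, a limit and not a number, so no step between compound 4 and compound 1, compound 2 or compound 3 can be read. The compounds shown leave open whether any of the four differs from another in the concentration tolerated.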